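The source may hold more compounds than are shown below. What is called first, only, known or untested is meant among the compounds shown, and "the series" means these compounds.

Compound 1 `COC(=O)Cn1c2ccc([N+](=O)[O-])cc2c(=O)n1Cc1ccccc1`: "not determined" (no result reported)
Compound 2 `O=[N+]([O-])c1ccc2nn(Cc3ccccc3)c(OCCCBr)c2c1`: 539000 nM

Within the data shown here, in an ADME assay on Vero cells (Chlorocebus sabaeus) for inhibition, read by fluorescence and resazurin assay, with a stated time of 24 h (a lower number here means that less compound is tolerated, a higher number that more compound is tolerated), compound 2 gives 539000 nM as the only number so far, since compound 1 has no reported result. Compound 3 `O=[N+]([O-])c1ccc2nn(Cc3ccccc3)c(OCCO)c2c1` carries hydroxy in place of bromomethyl on a saturated chain carbon, two bonds along the chain from an oxygen on an aromatic ring, turning 3-bromopropoxy into 2-hydroxyethoxy hydroxy in place of bromomethyl on a saturated chain carbon, two bonds along the chain from an oxygen on an aromatic ring in this pair. Among the measured compounds shown here, no measured pair shows what such a change does, so no shift beyond the usual scatter is expected in this assay and only a slight lean toward more compound tolerated. The estimated step of a 1.3-fold higher number from compound 2 to compound 3 (0.11 log units; within the scatter) is therefore small. Compound 3 is expected at 700000 nM within an estimated range from 250000 nM to 1500000 nM in this measurement.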

Compound 3, half-maximal cytotoxic concentration: > 300000 nM
Compound 3: a limit, no number (the forecaster's own chance of this, stated with the estimate: 30%); the middle value lies beyond the limit too.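

Compound 3 gives only a limit, not a number, so no step from compound 2 to compound 3 can be read: the limit of > 300000 nM in this assay, at which 1 of the 3 values shown sits.

Going by these compounds, whether 2-hydroxyethoxy in place of 3-bromopropoxy changes the result in this assay stays open.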